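The compounds below may be only part of what the source reports. "The series", "measured", "known", "first", "only" and "open" are said of these compounds alone.

Measured in a functional assay on the whole organism (heart) with Rattus norvegicus as the target; on this read-out higher numbers stand for an effect only at larger amounts of compound and lower numbers for an effect already at smaller amounts:
- Compound 1 `CC(=O)/C(=C\c1ccccc1)Oc1ccccc1OCC(C)N(C)C`: 0.9 mg/kg
- Compound 2 `CC(=O)/C(=C\c1ccccc1)Oc1ccccc1OCC(O)CNC(C)(C)C`: 1.9 mg/kg
- Compound 3 `CC(=O)/C(=C\c1ccccc1)Oc1ccccc1OCCCNC(C)(C)C`: 1.5 mg/kg

On this assay, compound 3 lies within the scatter of both other compounds, so the numbers do not separate it from either. Compound 4 `CC(=O)/C(=C\c1ccccc1)Oc1ccccc1OCCCN1CCCCC1` carries piperidin-1-yl in place of (tert-butyl)amino on a saturated chain carbon, three bonds along the chain from an oxygen on an aromatic ring.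

Among the compounds with values here, no measured step makes this exact exchange, so the evidence is indirect. The closest is a 1.7-fold higher number from compound 1 to compound 3 (0.22 log units; within the scatter), which also alters the amino group and stays within the scatter. The step of a 1.3-fold lower number from compound 2 to compound 3 (0.10 log units; within the scatter) also stays within it. Only a 2.1-fold higher number from compound 1 to compound 2 (0.32 log units; beyond the scatter) goes beyond the scatter, and it is modest. Across these three compounds, then, changes at this end of the chain moved the number little, though none of them contains a ring there.

The expected result is no change beyond the scatter, with a 1.2-fold lower number from compound 3 to compound 4 (0.06 log units; within the scatter) as the estimated step. For compound 4 the estimate is 1.3 mg/kg, with an expected range from 0.6 mg/kg to 3 mg/kg.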

Compound 4, dose for half-maximal effect: 0.2 mg/kg
For compound 4 the middle estimate is 6.5-fold (0.81 log units) above the measured one; measured number outside the range, below it.
By their numbers in this assay, from the lowest: compound 4; then compounds 1, 3 and 2 (each within the scatter of the next, the first and the last beyond it).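

Within the data shown here, putting piperidin-1-yl in place of (tert-butyl)amino in this assay gives a 7.5-fold lower number from compound 3 to compound 4 (0.88 log units; beyond the scatter) and is a larger step than any among the earlier compounds, so this end of the chain is less indifferent than they suggested. The change also sets the ring-bearing chain apart from the other two chains, with a 9.5-fold lower number from compound 2 to compound 4 (0.98 log units; beyond the scatter) and a 4.5-fold lower number from compound 1 to compound 4 (0.65 log units; beyond the scatter) leaving compound 4 with the lowest number of the four. The data shown hold nothing that explains this drop.

The compounds shown leave open whether pyrrolidin-1-yl, morpholin-4-yl or diethylamino at this place would give a similar number. They also leave open whether piperidin-1-yl would have the same effect on the hydroxy-bearing chain of compound 2 or on the branched chain of compound 1.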